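Compound 2 to compound 3: isopropoxy in place of iodo

A few compounds are considered here, and "the series" means these few. Any claim that something is new, unique, unknown or untested is made for them only; others in the source may bear on it.

In a functional assay on MCF7 cells (Homo sapiens) for inhibition, with a stated time of 48 h (a higher number here means a weaker inhibitor, a lower number a stronger inhibitor), compound 1 (`Cc1cc(C)cc(Sc2c[nH]c3ccc(Cl)cc23)c1`) gives 1200 nM and compound 2 (`COc1cc(Sc2c[nH]c3ccc(I)cc23)cc(OC)c1OC`) gives 68 nM as the lower of the two numbers. That gap lies beyond the scatter, which makes compound 2 the stronger inhibitor of this pair. For the measured compounds named here, no step between measured compounds that differ in one place is available yet, so the expectation below rests only on the structural change and on the position of compound 2 as the lower number.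

Compound 3 (`COc1cc(Sc2c[nH]c3ccc(OC(C)C)cc23)cc(OC)c1OC`) carries isopropoxy in place of iodo on an aromatic carbon of the shared core. The expected change is a 4.4-fold higher number from compound 2 to compound 3 (0.64 log units; beyond the scatter) in this assay toward a weaker inhibitor, though this estimate is uncertain. Compound 3 is estimated at 300 nM (expected range 60 nM to 1500 nM).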

Compound 3, half-maximal inhibitory concentration: 1500 nM
Estimate against measurement, compound 3: 5.0-fold (0.70 log units) below; measured number inside the range.
By their numbers in this assay, from the lowest: compound 2; then compounds 1 and 3 (each within the scatter of the next).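

In this assay, for the compounds shown here, the exchange of iodo for isopropoxy gives a 22-fold higher number from compound 2 to compound 3 (1.34 log units; beyond the scatter) as the first step that changes a single place, and it runs toward a weaker inhibitor. The read-out is therefore sensitive to the group on this aromatic carbon, and isopropoxy is not tolerated here as well as iodo. Nothing available bears on the reason for the rise, so the step cannot be assigned to the loss of iodine, the added oxygen or the larger heavy-atom count.

Open, as far as these compounds go, is how a nitrile, an amine or a carboxylic acid on this carbon would compare with iodo and isopropoxy. From the compounds shown here alone, a single step also sets no trend, so whether the same exchange would have a similar effect with other groups on the shared core remains unknown.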